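Trimming the benzyl ether of compound 1 to ethyl

The source may report more compounds than this note shows. Statements on the series, on what has been measured and on what is new or still open speak of the compounds shown alone.

Compound 1 `CN(C)CCNc1ccnc2cc(OCc3ccc(F)cc3)ccc12` gives the lowest number of the three measured compounds in a functional assay on SK-OV-3 cells (Homo sapiens) for cytotoxicity, read by MTT assay, with a stated time of 48 h (on this read-out lower numbers stand for stronger inhibition and higher numbers for weaker inhibition), namely 890 nM. Its nearest neighbour, compound 2 `CN(C)CCCNc1ccnc2cc(OCc3ccc(F)cc3)ccc12`, gives 1280 nM; the step of a 1.4-fold higher number from compound 1 to compound 2 (0.16 log units; within the scatter) lies within the scatter. The furthest is compound 3 `Clc1ccnc2cc(OCCCc3ccccc3)ccc12`, which gives 3610 nM, beyond the scatter from compound 1.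

Compound 4 `CCOc1ccc2c(NCCN(C)C)ccnc2c1` differs from compound 1 by methyl in place of 4-fluorophenyl on a saturated chain carbon bound to an oxygen on an aromatic ring. For the measured compounds named here, none of the measured steps bears directly on this change: the single one-place step, from compound 1 to compound 2, concerns the amine chain and not the ether, and compound 3 differs from compound 1 in more than one place, so its value can only be read as a separate number. Going by the values given here, with no measured step for this change, the expectation rests on the size of what leaves against what enters, and compound 4 is estimated to give 3000 nM in this assay, between 900 nM and 10000 nM, which would mean the step of a 3.4-fold higher number from compound 1 to compound 4 (0.53 log units; beyond the scatter) is expected to be a loss, though the range also allows a step within the scatter.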

Compound 4, half-maximal inhibitory concentration: 4620 nM
Beside the measured number, compound 4's estimate is 1.5-fold (0.19 log units) below it; low and high end bracket the measured number.
By their numbers in this assay, from the lowest: compounds 1 and 2 (each within the scatter of the next); then compounds 3 and 4 (each within the scatter of the next).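

In this assay, cutting 4-fluorobenzyl back to ethyl gives a 5.2-fold higher number from compound 1 to compound 4 (0.72 log units; beyond the scatter), so this change on the saturated chain carbon bound to an oxygen on an aromatic ring is a loss beyond the scatter. The earlier one-place step concerned the amine chain and stayed within the scatter, which makes this the first single change shown to move the number beyond it. The 4-fluorophenyl therefore cannot be exchanged for methyl here without a loss, but no measurement at hand explains why.

The compounds shown do not separate the part played by the fluorine from that of the aromatic ring, since neither plain benzyl nor 4-chlorobenzyl is among them. On these data alone, it also stays open how a longer chain such as propyl or butyl on the same oxygen would read.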